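A new group on the carbonyl of compound 2

The source may hold more compounds than are shown below. What is called first, only, known or untested is meant among the compounds shown, and "the series" means these compounds.

In an ADME assay on Caco-2 cells (Homo sapiens) for permeability, in the apical to basolateral direction, with a stated time of 90 min, tested at 10 uM (a lower number here means that the compound crosses the layer more slowly, a higher number that the compound crosses the layer faster), compound 2 `O=C(NC[C@@H]1[C@H]2CN(C(=O)C3CC3c3cc(Cl)cc(Cl)c3)C[C@@H]12)c1ccc2[nH]c(=O)oc2c1` gives 64 10^-6 cm/s and compound 3 `O=C(NC[C@@H]1[C@H]2CN(C(=O)N3CCc4c(Cl)cc(Cl)cc4C3)C[C@@H]12)c1ccc2[nH]c(=O)oc2c1` gives 47 10^-6 cm/s so the two lie within the usual scatter of each other. Compound 1 `O=C(NC[C@@H]1[C@H]2CN(C(=O)CCc3cc(Cl)cc(Cl)c3)C[C@@H]12)c1ccc2[nH]c(=O)oc2c1` stands apart at 18 10^-6 cm/s on the same scale.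

Compound 4 `Cc1cc(COC(=O)N2C[C@@H]3[C@@H](CNC(=O)c4ccc5[nH]c(=O)oc5c4)[C@@H]3C2)no1` shares the core of compound 2 and differs in one place, with a group of 8 heavy atoms (5 carbon, 1 nitrogen, 2 oxygen; one five-membered aromatic ring with 2 hetero atoms) in place of a group of 11 heavy atoms (9 carbon, 2 chlorine; one three-membered non-aromatic ring of carbon only, one six-membered aromatic ring of carbon only), on a carbonyl carbon here. The group that enters is (5-methyl-1,2-oxazol-3-yl)methoxy, and the other neighbour of that carbonyl carbon is an amide-type nitrogen in a ring.

For the measured compounds named here, only one measured step bears directly on this carbonyl carbon. That step, a 3.6-fold higher number from compound 1 to compound 2 (0.55 log units; beyond the scatter) shows that a swap in this place can move the number beyond the scatter, although it exchanged one chlorine-bearing group for another. Going by the values given here, no measured compound carries a five-membered aromatic ring with 2 hetero atoms in this place, so the direction is a judgement and not a reading from the data. A downward step of similar size is expected, an estimated 2.6-fold lower number from compound 2 to compound 4 (0.41 log units; beyond the scatter) in this assay for this swap. For compound 4 the estimated value is 25 10^-6 cm/s with an expected range from 10 10^-6 cm/s to 55 10^-6 cm/s in this measurement.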

Compound 4, apparent permeability: 2 10^-6 cm/s
Beside the measured number, compound 4's estimate is 13-fold (1.10 log units) above it, outside the stated range (below it).
By their numbers in this assay, from the lowest: compound 4; then compound 1; then compounds 3 and 2 (each within the scatter of the next).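

Putting (5-methyl-1,2-oxazol-3-yl)methoxy on this carbonyl carbon gives a 32-fold lower number from compound 2 to compound 4 (1.51 log units; beyond the scatter) in this assay, a far bigger move than the earlier exchange of one chlorine-bearing group for another, a 3.6-fold higher number from compound 1 to compound 2 (0.55 log units; beyond the scatter), so this place can shift the number much further than the first compounds suggested. The drop does not depend on compound 2 alone as the starting point: set against 2-(3,5-dichlorophenyl)ethyl, the same entering group gives a 9.0-fold lower number from compound 1 to compound 4 (0.95 log units; beyond the scatter), which is a smaller step but still beyond the scatter. Several things change at once in this swap, as both chlorines and the carbon-only rings leave while a five-membered aromatic ring with 2 hetero atoms enters, and nothing measured here explains the drop.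

As far as these compounds go, it remains open whether the low number follows the oxygen that now joins the group to the carbonyl carbon or follows the ring itself. A (3,5-dichlorophenyl)methoxy group, or a 2-(5-methyl-1,2-oxazol-3-yl)ethyl group, on this carbonyl carbon would pull those two changes apart.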